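Amino in Place of Methylsulfanyl on a Shared Nucleoside Core

The source may hold more compounds than are shown below. What is called first, only, known or untested is meant among the compounds shown, and "the series" means these compounds.

Compound 1, `CSc1nc(SC)c2ncn([C@@H]3C[C@@H](O)[C@H](CO)O3)c2n1`, gives 225 uM in a functional assay on B-95-8 cells (Cercopithecidae) with B-95-8 cell line (Saguinus oedipus) as the target; a lower number here means a stronger inhibitor, a higher number a weaker inhibitor.
Compound 2, `CNc1nc(Br)nc2c1ncn2[C@@H]1C[C@@H](O)[C@H](CO)O1`, gives 253 uM in this assay.

Both measured compounds are weak inhibitors. Within the data shown here, compound 1 has the lowest of the two numbers, but compound 2 lies within the usual scatter of it, so the two values cannot be placed in any order; they show only that both compounds sit in the same weak range.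

Compound 3, `CSc1nc(N)c2ncn([C@@H]3C[C@@H](O)[C@H](CO)O3)c2n1`, is the next compound to be measured. It differs from compound 1 in one place: amino in place of methylsulfanyl on an aromatic carbon. Among the measured compounds shown here, no pair of measured compounds shows what such a change does, so there is no measured step to lean on. With nothing pointing either way, the expectation is a step of no more than the scatter, in no particular direction, keeping compound 3 in the weak range of compound 1 and compound 2. Compound 3 is therefore estimated at 200 uM in this assay, with a range from 60 uM to 600 uM. This estimate means an expected step of a 1.1-fold lower number from compound 1 to compound 3 (0.05 log units; within the scatter).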

Compound 3, concentration for 50% inhibition: > 300 uM
Compound 3 gave a limit, no number (the forecaster's own chance of this, stated with the estimate: 20%); at least 1.5-fold (0.17 log units) between middle value and limit.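

Compound 3 gives a limit of the assay rather than a number: > 300 uM in this assay. This is the first measured step for amino in place of methylsulfanyl on this aromatic carbon, and the change gives an at least 1.3-fold higher number from compound 1 to compound 3 (0.12 log units; that floor lies within the scatter), so the swap brings no gain in strength here, although a real loss is not shown either. The step has a floor and no full size because the reading for compound 3 stops at a limit: the limit of > 300 uM in this assay, at which 1 of the 3 values shown sits.

From the compounds shown here alone, it remains open how far compound 3 truly lies from compound 1, and so whether this change matters at all beyond the usual scatter of repeated measurements. The compounds shown also leave unanswered what a hydroxyl group or a longer sulfur chain such as ethylsulfanyl would do on this same carbon, and whether any group placed there can move the number out of the weak range shared by these compounds.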